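Piperazine nitrogen substituent: methyl to pyrimidin-2-yl

The source may report more compounds than this note shows. Statements on the series, on what has been measured and on what is new or still open speak of the compounds shown alone.

Three compounds of the series share a core and differ only in the group on the amine nitrogen of the six-membered ring with two nitrogens. Compound 1 `Nc1ccccc1NC(=O)c1ccc(CSC(=S)N2CCN(c3ccc(F)cc3)CC2)cc1` carries a 4-fluorophenyl there and in a functional assay on A-375 cells (Homo sapiens) for antiproliferative activity, read by CCK-8 assay, with a stated time of 72 h, tested at 8 uM (a higher number here means a stronger effect of the compound at the concentration tested, a lower number a weaker effect), compound 1 gives 76.3%. Compound 2 `N#Cc1ccc(N2CCN(C(=S)SCc3ccc(C(=O)Nc4ccccc4N)cc3)CC2)cc1` carries a 4-cyanophenyl, and in this assay compound 2 gives 62.9%. Compound 3 `CN1CCN(C(=S)SCc2ccc(C(=O)Nc3ccccc3N)cc2)CC1` carries a methyl, and in this assay compound 3 gives 91.6%, the highest of the three numbers; the nearest is compound 1, the furthest compound 2.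

Compound 4 `Nc1ccccc1NC(=O)c1ccc(CSC(=S)N2CCN(c3ncccn3)CC2)cc1` is not yet measured. It differs from compound 3 by pyrimidin-2-yl in place of methyl on an amine nitrogen in a ring.

Among the compounds with values here, the steps that bear on this change are those in which methyl replaced an aromatic ring on the same nitrogen: a number 15.3 percentage points higher from compound 1 to compound 3 (beyond the scatter) and a number 28.7 percentage points higher from compound 2 to compound 3 (beyond the scatter). Both run upward toward methyl. Compound 4 moves the other way, from methyl back to a six-membered aromatic ring, so a decrease beyond the scatter is expected, of a size between those two steps; it is estimated as a number 19.6 percentage points lower from compound 3 to compound 4 (beyond the scatter).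

Compound 4 in this assay is expected to give 72%, within a range of 55% to 88%.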

Compound 4, a percentage reported as inhibition, at one concentration (the size of the read-out at that concentration, not a potency): 67.9%
Compound 4: the middle estimate sits 4.1 percentage points above what was measured, and the stated range covers the measured number.
By their numbers in this assay, from the lowest: compounds 2, 4 and 1 (each within the scatter of the next, the first and the last beyond it); then compound 3.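

In this assay, the step of a number 23.7 percentage points lower from compound 3 to compound 4 (beyond the scatter) adds a third six-membered aromatic ring on the amine nitrogen, and a ring with two nitrogens in it also falls beyond the scatter from the methyl of compound 3, as the two phenyl groups did. Among the groups shown, the separation therefore lies between methyl and all three aromatic rings, while the steps of a number 5 percentage points higher from compound 2 to compound 4 (within the scatter) and a number 8.4 percentage points lower from compound 1 to compound 4 (within the scatter) are both within the scatter, so pyrimidin-2-yl cannot be told apart from either substituted phenyl group. Nothing at hand gives a measured reason for the gap between methyl and the aromatic rings at this nitrogen.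

The compounds shown leave open whether the level of compound 3 is particular to methyl or extends to other non-aromatic groups on this nitrogen, such as ethyl, cyclopropyl or acetyl. They also leave open how a benzyl group would read, and whether the stronger and weaker effects seen at this single concentration would hold at other concentrations.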